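A few compounds are considered here, and "the series" means these few. Any claim that something is new, unique, unknown or untested is made for them only; others in the source may bear on it.

Measured so far:
Compound 1, `CCn1c(-c2cnc(C)nc2)nc2c(N[C@H]3CCN(C(=O)C4CC(F)(F)C4)C3)ncnc21`, gives 0.4 h in an ADME assay (Rattus norvegicus, strain Wistar Han) for metabolic stability; a lower number here means that the compound disappears faster, a higher number that the compound lasts longer.
Compound 2, `CCn1c(-c2ccc(C(F)(F)F)nc2)nc2c(O[C@H]3CCN(C(=O)N4CC(OC)C4)C3)ncnc21`, gives 2 h in this assay.
Compound 3, `CCn1c(-c2ccc(C(F)(F)F)nc2)nc2c(O[C@H]3CCN(C(=O)C4CCOC4)C3)ncnc21`, gives 2.3 h in this assay.

Compound 1 stands lowest of the three numbers. Compound 2 and compound 3 share a different core from compound 1, and the values of compound 2 and compound 3 lie within the scatter of one another; both sit well beyond the scatter above compound 1.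

Compound 4, `CCn1c(-c2cnc(C)nc2)nc2c(N[C@H]3CCN(C(=O)C4CCOCC4)C3)ncnc21`, has not yet been measured. It differs from compound 1 in one place: oxan-4-yl in place of 3,3-difluorocyclobutyl on a carbonyl carbon. Within the data shown here, the only measured step that also changes the group on a carbonyl carbon is a 1.2-fold higher number from compound 2 to compound 3 (0.06 log units; within the scatter), and that step lay within the scatter, though on the other core and with different groups. Among the measured compounds shown here, no measured pair shows this exact exchange. On that thin evidence the change is expected to move the half-life little, with a 1.5-fold higher number from compound 1 to compound 4 (0.18 log units; within the scatter) as the estimated step. Compound 4 is therefore estimated at 0.6 h, within a range from 0.25 h to 1.5 h.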

Compound 4, half-life: 1.4 h
For compound 4 the middle estimate is 2.3-fold (0.37 log units) below the measured one; low and high end bracket the measured number.
By their numbers in this assay, from the lowest: compound 1; then compounds 4, 2 and 3 (each within the scatter of the next).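

On the core of compound 1, oxan-4-yl in place of 3,3-difluorocyclobutyl on a carbonyl carbon gives, in this assay, a 3.5-fold higher number from compound 1 to compound 4 (0.54 log units; beyond the scatter). Among these compounds, this shows that a change of group at this place can move the half-life beyond the scatter, which the only earlier step at such a place, a 1.2-fold higher number from compound 2 to compound 3 (0.06 log units; within the scatter), did not show; that step lay on another core and involved other groups. No available measurement bears on what lies behind the new step.

A single pair cannot separate the loss of 3,3-difluorocyclobutyl from the arrival of oxan-4-yl, and the compounds shown leave open where a plain cyclobutyl or a cyclohexyl on the same carbonyl carbon would stand. They also leave open whether this exchange would move the half-life on the core shared by compound 2 and compound 3.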